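The source may report more compounds than this note shows. Statements on the series, on what has been measured and on what is new or still open speak of the compounds shown alone.

Measured compounds:
compound 1 `O=C(Nc1cccc(C(F)(F)F)c1)N[C@H]1CC[C@H](O)CC1` — > 20000 nM
compound 2 `O=C(Nc1ccccc1[N+](=O)[O-])N[C@H]1CC[C@H](Oc2ccc(F)cc2)CC1` — 3500 nM
compound 3 `O=C(Nc1ccccc1Cl)N[C@H]1CC[C@H](Oc2ccc(F)cc2)CC1` — 9100 nM

Three ureas were tested in a functional assay on CRL2813 cells (Homo sapiens) for cytotoxicity, read by sulforhodamine B assay, with a stated time of 5 days; a lower number here means a stronger inhibitor, a higher number a weaker inhibitor. Compound 1 gives > 20000 nM, which is a limit of the assay rather than a number; compound 1 sits at the limit of > 20000 nM in this assay, at which 1 of the 3 values shown sits. Compound 2 gives 3500 nM and compound 3 gives 9100 nM. Within the data shown here, the one step measured between compounds differing in a single place is a 2.6-fold higher number from compound 2 to compound 3 (0.41 log units; beyond the scatter); it concerns the aromatic ring of the urea, not the oxygen on the saturated carbon, so it does not bear on the change considered here. Compound 4 `O=C(Nc1cccc(C(F)(F)F)c1)N[C@H]1CC[C@H](Oc2ccc(Cl)cc2)CC1` differs from compound 1 by 4-chlorophenyl in place of hydrogen on an oxygen on a saturated carbon. Among the measured compounds shown here, no measured step covers this change; the only guide is that compound 2 and compound 3, which carry an aromatic ring on the oxygen on the saturated carbon, give numbers inside the assay range, while compound 1 with a free hydroxy stands at the limit. Compound 4 is therefore expected to give a measured number, estimated at 5000 nM with a range of 1500 nM to 20000 nM. This corresponds to an expected at least 4.0-fold lower number from compound 1 to compound 4 (0.60 log units; beyond the scatter).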

Compound 4, half-maximal inhibitory concentration: 2000 nM
Estimate against measurement, compound 4: 2.5-fold (0.40 log units) above; the range from low to high includes it.
By their numbers in this assay, from the lowest: compounds 4 and 2 (each within the scatter of the next); then compound 3. At a limit, above all of these: compound 1.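

In this assay, among these compounds, 4-chlorophenyl in place of hydrogen on the oxygen on a saturated carbon gives an at least 10-fold lower number from compound 1 to compound 4 (1.00 log units; beyond the scatter), and this is the first comparison of hydroxy and 4-chlorophenoxy with the rest of the molecule held the same. Compounds 2 and 3 could not show this, as each differs from compound 1 in more than one place. Compound 1 gives > 20000 nM, which is a limit of the assay and not a number, so the step sets only a minimum size for this change: the limit of > 20000 nM in this assay, at which 1 of the 4 values shown sits.

The compounds shown leave open whether the 4-chlorophenyl group itself is needed, or whether a methyl, a benzyl or an unsubstituted phenyl on the same oxygen would give a similar result. Compound 4 differs from compound 2 and compound 3 in more than one place, so those comparisons cannot be read as steps.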